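Chlorophenyl position in the sulfamoylphenyl series: cytotoxicity notes

The source may report more compounds than this note shows. Statements on the series, on what has been measured and on what is new or still open speak of the compounds shown alone.

In an ADME assay on MT4 cells (Homo sapiens) for cytotoxicity, read by MTT assay, with a stated time of 96 h (on this read-out lower numbers stand for higher toxicity in this test and higher numbers for lower toxicity in this test), compound 1 (`NS(=O)(=O)c1ccc(N2N=C(c3ccc(OCc4ccccc4)cc3)CC2c2ccc(Cl)cc2)cc1`) gives 70000 nM and compound 2 (`NS(=O)(=O)c1ccc(N2N=C(c3ccc(Oc4ccccc4)cc3)CC2c2cccc(Cl)c2)cc1`) gives 8000 nM. Compound 2 holds the lower of the two numbers, with a gap beyond the scatter. Compound 3 (`NS(=O)(=O)c1ccc(N2N=C(c3ccc(Oc4ccccc4)cc3)CC2c2ccc(Cl)cc2)cc1`) departs from compound 2 at one place: 4-chlorophenyl in place of 3-chlorophenyl on a saturated ring carbon. Going by the values given here, no measured step isolates this change. Compound 1 also bears 4-chlorophenyl but differs elsewhere, so its 70000 nM offers only a weak hint of an upward move. The expected change is a modest rise, a 1.8-fold higher number from compound 2 to compound 3 (0.24 log units; within the scatter). For compound 3 the estimate is 14000 nM, with an expected range of 5000 nM to 40000 nM.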

Compound 3, half-maximal cytotoxic concentration: 9000 nM
Estimate against measurement, compound 3: 1.6-fold (0.19 log units) above; the range from low to high includes it.
By their numbers in this assay, from the lowest: compounds 2 and 3 (each within the scatter of the next); then compound 1.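

In this assay, 4-chlorophenyl in place of 3-chlorophenyl on the saturated ring carbon gives a 1.1-fold higher number from compound 2 to compound 3 (0.05 log units; within the scatter) and so does not separate these two chlorophenyl groups. The clear difference lies at the other place, where phenyl in place of benzyl on the oxygen gives a 7.8-fold lower number from compound 1 to compound 3 (0.89 log units; beyond the scatter) as a step beyond the scatter. No measured evidence bears on the reason for either step.

Still open, as far as these compounds go, is how an amine or a carboxylic acid on this phenyl ring would read in this test. From the compounds shown here alone, a longer chain on the oxygen is also open.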